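Cytotoxicity notes: replacing the acetyl of compound 2

The compounds below may be only part of what the source reports. "The series", "measured", "known", "first", "only" and "open" are said of these compounds alone.

Measured in an ADME assay on MDBK cells (Bos taurus) for cytotoxicity, read by MTT assay, with a stated time of 96 h; on this read-out higher numbers stand for lower toxicity in this test and lower numbers for higher toxicity in this test:
- compound 1 `CC(=O)c1ccc2[nH]c(-c3ccc(C(F)(F)F)cc3)nc2c1`: > 100000 nM (a limit)
- compound 2 `CC(=O)c1ccc2c(c1)nc(-c1ccc(C(F)(F)F)cc1)n2C1CCCCC1`: 52000 nM
- compound 3 `COc1ccc(-c2nc3cc(C(C)=O)ccc3n2C2CCCCC2)cc1`: > 100000 nM (a limit)

Among the compounds with values here, compound 2, at 52000 nM, holds the only actual number in the set. The other two values are limits. Compound 4 `C/C(=N\NC(N)=O)c1ccc2c(c1)nc(-c1ccc(C(F)(F)F)cc1)n2C1CCCCC1` replaces its acetyl: a group of 7 heavy atoms (3 carbon, 3 nitrogen, 1 oxygen; no ring) in place of a group of 3 heavy atoms (2 carbon, 1 oxygen; no ring), on an aromatic carbon. Two measured steps involve compound 2: an at least 1.9-fold lower number from compound 1 to compound 2 (0.28 log units; that floor lies within the scatter) and an at least 1.9-fold higher number from compound 2 to compound 3 (0.28 log units; that floor lies within the scatter). Within the data shown here, neither changes the acetyl, so they bear on compound 4 only indirectly, and no measured step covers this change. In this assay, no step beyond the scatter is therefore expected, in either direction. The expected step is a 1.3-fold lower number from compound 2 to compound 4 (0.11 log units; within the scatter). For compound 4 the estimate is 40000 nM, with an expected range of 15000 nM to 100000 nM.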

Compound 4, half-maximal cytotoxic concentration: > 100000 nM
Compound 4: only a limit was reported; the forecaster's own chance of this, stated with the estimate: 25%; middle value at least 2.5-fold (0.39 log units) from the limit.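

Replacing the acetyl on this aromatic carbon with the group of 7 heavy atoms gives an at least 1.9-fold higher number from compound 2 to compound 4 (0.28 log units; that floor lies within the scatter) in this assay. This is the first change shown at this position, and it gives no sign of added toxicity in this test. The value for compound 4 is a limit, so the step is only a floor: the limit of > 100000 nM in this assay, at which 3 of the 4 values shown sit.

On these data alone, whether an amine or a carboxylic acid on this carbon would give a number short of that limit stays open. So does the effect of the same replacement on compound 3, with methoxy in place of trifluoromethyl.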